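Changing the amide side chain of compound 3

The compounds below may be only part of what the source reports. "The series", "measured", "known", "first", "only" and "open" are said of these compounds alone.

Of the compounds shown here, three sharing one core have been measured in a functional assay on EBC-1 cells (Homo sapiens) for antiproliferative activity, with a stated time of 72 h; on this read-out higher numbers stand for weaker inhibition and lower numbers for stronger inhibition. Compound 1 `COc1ccc(-c2cc(F)c3ncc(Cc4ccc5ncccc5c4)n3c2)cc1F` gives 407 nM, and compound 2 `O=C(c1ccc(-c2cc(F)c3ncc(Cc4ccc5ncccc5c4)n3c2)cc1F)N1CCC2(COC2)C1` gives 406 nM. The step between them is a 1.0-fold lower number from compound 1 to compound 2 (0.00 log units; within the scatter). Compound 3 `CN(C)CCNC(=O)c1ccc(-c2cc(F)c3ncc(Cc4ccc5ncccc5c4)n3c2)cc1F` gives 49 nM, the lowest number of the three. Compound 4 `O=C(NC1CCCNC1)c1ccc(-c2cc(F)c3ncc(Cc4ccc5ncccc5c4)n3c2)cc1F` keeps the core and the amide of compound 3 and differs only on the amide-type nitrogen: piperidin-3-yl in place of 2-(dimethylamino)ethyl on an amide-type nitrogen. In words, piperidin-3-yl stands in place of 2-(dimethylamino)ethyl.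

For the measured compounds named here, no measured step makes this exact change, so the evidence is indirect. The two steps that bear on it are an 8.3-fold lower number from compound 1 to compound 3 (0.92 log units; beyond the scatter) and an 8.3-fold lower number from compound 2 to compound 3 (0.92 log units; beyond the scatter), both modest. Compound 2 also carries an amide, at 406 nM, so among these three compounds an amide alone does not go with the low number. The entering group, like the one it replaces, holds a hydrogen-bond acceptor, but it adds a ring and a hydrogen-bond donor, and the data do not show how either counts. Little change is therefore expected, with a slight lean towards a higher number. The expected step is a 1.4-fold higher number from compound 3 to compound 4 (0.15 log units; within the scatter), which would stay within the scatter. In this assay the estimate for compound 4 is 70 nM, with an expected range from 25 nM to 200 nM.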

Compound 4, half-maximal inhibitory concentration: 138 nM
The estimate for compound 4 lay 2.0-fold (0.29 log units) below the measured number; measured number inside the range.
By their numbers in this assay, from the lowest: compound 3; then compound 4; then compounds 2 and 1 (each within the scatter of the next).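

In this assay, for the compounds shown here, the side chain on the amide-type nitrogen proved not to be interchangeable: piperidin-3-yl in place of 2-(dimethylamino)ethyl gave a measurable loss (in numbers, a 2.8-fold higher number from compound 3 to compound 4 (0.45 log units; beyond the scatter)), so this nitrogen responds to a change that the earlier compounds had not tested directly. Compound 4 nevertheless keeps part of the advantage that compound 3 holds over the other two compounds, as both remaining steps show (a 2.9-fold lower number from compound 2 to compound 4 (0.47 log units; beyond the scatter); a 2.9-fold lower number from compound 1 to compound 4 (0.47 log units; beyond the scatter)), so the low numbers do not depend on the open 2-(dimethylamino)ethyl chain alone. No measurement on hand explains why the ring-bearing side chain gives the higher number than the open chain.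

The change brings in a ring and a hydrogen-bond donor together, so the compounds shown cannot say which of the two goes with the step from compound 3 to compound 4. A 1-methylpiperidin-3-yl group would keep the ring without that donor, and an open chain ending in methylamino would keep the donor without the ring, while a longer chain such as 3-(dimethylamino)propyl would test the length of the open chain.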